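Swapping the Outer Aromatic Ring for an Amide-Bearing Chain

The compounds below may be only part of what the source reports. "The series", "measured", "known", "first", "only" and "open" are said of these compounds alone.

Measured compounds:
compound 1 `COC(=O)/C=C/c1cccc(N(Cc2ccc(-c3cccc(C)c3)cc2)C(=O)C2CCCCC2)c1`: 109 nM
compound 2 `COC(=O)/C=C/c1cccc(N(Cc2ccc(-c3cccc(C)c3)cc2)C(=O)C(C)C)c1`: 163 nM
compound 3 `COC(=O)/C=C/c1cccc(N(Cc2cccc(OC)c2)C(=O)C2CCCCC2)c1`: > 1000 nM

In an assay on isolated protein with Bile acid receptor (Homo sapiens) as the target (on this read-out lower numbers stand for an effect already at smaller amounts and higher numbers for an effect only at larger amounts of compound), compound 1 gives 109 nM. Compound 2 differs from it only at the carbonyl carbon, isopropyl in place of cyclohexyl, and the gap is a 1.5-fold higher number from compound 1 to compound 2 (0.17 log units; within the scatter). For compound 3 this assay reports only a limit, > 1000 nM. Compound 4 `COC(=O)/C=C/c1cccc(N(Cc2ccc(/C=C/C(=O)N(C)C)cc2)C(=O)C2CCCCC2)c1` keeps the cyclohexyl carbonyl of compound 1 but changes the distant end: 2-(dimethylcarbamoyl)ethenyl in place of 3-methylphenyl on an aromatic carbon. Among the compounds with values here, no measured step covers this kind of exchange; the one measured step concerns the carbonyl side and stays within the scatter. Compound 3 shows that changing this end of the molecule can push the value to the limit. A weaker result is therefore expected for compound 4, a step of a 3.7-fold higher number from compound 1 to compound 4 (0.56 log units; beyond the scatter), giving an estimate of 400 nM with a range from 120 nM to 1500 nM.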

Compound 4, half-maximal effective concentration: > 1000 nM
Compound 4: no number, only a limit (the forecaster's own chance of this, stated with the estimate: 30%); middle value at least 2.5-fold (0.39 log units) from the limit.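

Within the data shown here, exchanging 3-methylphenyl for 2-(dimethylcarbamoyl)ethenyl on this aromatic carbon gives an at least 9.1-fold higher number from compound 1 to compound 4 (0.96 log units; beyond the scatter), the first single-place change here that lies beyond the scatter. This distant end therefore counts for more in these pairs than the group on the carbonyl, where the change gives a 1.5-fold higher number from compound 1 to compound 2 (0.17 log units; within the scatter). The true size of the step stays unknown because compound 4 sits at a limit: the limit of > 1000 nM in this assay, at which 2 of the 4 values shown sit.

Still open, on these data alone, is whether an unsubstituted phenyl ring here would keep a value close to that of compound 1. Also open, as far as these compounds go, is whether a carboxylic acid in place of the dimethylamide on the ethenyl chain would do so.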